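The source may report more compounds than this note shows. Statements on the series, on what has been measured and on what is new or still open speak of the compounds shown alone.

Working notes on the series. In a functional assay on MKN-74 cells (Homo sapiens) for antiproliferative activity, with a stated time of 24 h (a higher number here means a weaker inhibitor, a lower number a stronger inhibitor), compound 1 `NC(=O)c1c(NC(=O)c2ccccc2Cl)sc2c1CCN(Cc1ccccc1Cl)C2` gives 4430 nM, compound 2 `NC(=O)c1c(NC(=O)c2ccccc2Cl)sc2c1CCN(Cc1ccc(Cl)cc1)C2` gives 18700 nM, and compound 3 `NC(=O)c1c(NC(=O)c2ccccc2Cl)sc2c1CCN(Cc1ccc([N+](=O)[O-])cc1)C2` gives 31500 nM. Compound 3 carries the highest number of the three; its gap to compound 2 stays within the scatter, while the step from compound 1 is a 7.1-fold higher number from compound 1 to compound 3 (0.85 log units; beyond the scatter). Compound 4 `NC(=O)c1c(NC(=O)c2ccccc2Cl)sc2c1CCN(C(=S)Nc1ccccc1)C2` differs from compound 3 by a group of 9 heavy atoms (7 carbon, 1 nitrogen, 1 sulfur; one six-membered aromatic ring of carbon only) in place of a group of 10 heavy atoms (7 carbon, 1 nitrogen, 2 oxygen; one six-membered aromatic ring of carbon only), on an amine nitrogen in a ring. The steps of a 4.2-fold higher number from compound 1 to compound 2 (0.63 log units; beyond the scatter) and a 7.1-fold higher number from compound 1 to compound 3 (0.85 log units; beyond the scatter) show that changes on this ring amine nitrogen shift this assay modestly; none of them swaps the benzyl group for a thiourea, so direction is open. A modest move is expected, a 3.5-fold lower number from compound 3 to compound 4 (0.54 log units; beyond the scatter). Compound 4 is estimated at 9000 nM, range 2200 nM to 36000 nM.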

Compound 4, half-maximal inhibitory concentration: 15600 nM
For compound 4 the middle estimate is 1.7-fold (0.24 log units) below the measured one, and the stated range covers the measured number.
By their numbers in this assay, from the lowest: compound 1; then compounds 4, 2 and 3 (each within the scatter of the next, the first and the last beyond it).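

In this assay, a thiourea on the amine nitrogen in a ring sits among the benzyl compounds, not apart from them (a 2.0-fold lower number from compound 3 to compound 4 (0.31 log units; beyond the scatter); a 1.2-fold lower number from compound 2 to compound 4 (0.08 log units; within the scatter)). The 2-chlorophenyl compound keeps the lowest number (a 3.5-fold higher number from compound 1 to compound 4 (0.55 log units; beyond the scatter)), so losing the benzyl group brings no gain over compound 1. No supporting data bear on this change. Still open, from the compounds shown here alone, is whether a urea, with oxygen in place of the thiourea sulfur, would track compound 4, and whether a short alkyl chain in place of the phenyl ring would shift the number.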